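Swapping an ester for a bromophenyl on the coumarin-like core

The source may report more compounds than this note shows. Statements on the series, on what has been measured and on what is new or still open speak of the compounds shown alone.

Three compounds share a core that carries a lipoic-acid-derived amide joined through a triazole. Compound 1 `O=C(CCCCC1CCSS1)NCc1cn(CCCOc2ccc3cc(-c4ccccc4)c(=O)oc3c2)nn1` gives 33.9% in a functional assay on PC-12 cells (Rattus norvegicus) for cytotoxicity, read by MTT assay, with stated times of 3 h and 2 h, tested at 0.1 uM; on this read-out lower numbers stand for a weaker effect and higher numbers for a stronger effect at the one concentration tested; compound 2 `COc1ccc(-c2cc3ccc(OCCCn4cc(CNC(=O)CCCCC5CCSS5)nn4)cc3oc2=O)cc1` gives 42%; compound 3 `CCOC(=O)c1cc2ccc(OCCCCCn3cc(CNC(=O)CCCCC4CCSS4)nn3)cc2oc1=O` gives 34.4%. Among the measured compounds shown here, the one single-point step, a number 8.1 percentage points higher from compound 1 to compound 2 (within the scatter), lies within the scatter, and compound 3 sits within the scatter of both compound 1 and compound 2. Compound 4 `O=C(CCCCC1CCSS1)NCc1cn(CCCCCOc2ccc3cc(-c4ccc(Br)cc4)c(=O)oc3c2)nn1` differs from compound 3 by 4-bromophenyl in place of ethoxycarbonyl on an aromatic carbon. For the measured compounds named here, no measured step covers this change; the only step known concerns a methoxy group and was within the scatter. Compound 4 is therefore expected to show a step of a number 2.6 percentage points higher from compound 3 to compound 4 (within the scatter), no more than the scatter. Compound 4 is estimated at 37%, within 27% to 47%.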

Compound 4, a percentage reported as activity, at one concentration (the size of the read-out at that concentration, not a potency): 41.8%
For compound 4 the middle estimate is 4.8 percentage points below the measured one; the measured number falls inside the stated range.
By their numbers in this assay, from the lowest: compounds 1, 3, 4 and 2 (each within the scatter of the next).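

In this assay, this aromatic carbon, two atoms from the ring oxygen, tolerates a large swap, as 4-bromophenyl in place of ethoxycarbonyl gives a number 7.4 percentage points higher from compound 3 to compound 4 (within the scatter). The entering group brings a six-membered aromatic ring and bromine and has no hydrogen-bond acceptors, whereas the leaving ester has two, yet the step stays within the scatter. No measured evidence bears on this result. Still open, from the compounds shown here alone, is whether a carboxylic acid or an amine at this position would also stay within the scatter, or whether any group here can produce a step beyond it.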